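The compounds below may be only part of what the source reports. "The series", "measured", "known", "first", "only" and "open" are said of these compounds alone.

Three analogues of the shared core of compound 1 `Cc1ccc(-c2cs/c(=N/NC(=O)CSc3nnnn3-c3ccccc3)n2-c2ccccc2)cc1` have been run in a functional assay on C6 cells (Rattus norvegicus) for cytotoxicity, read by MTT assay, with a stated time of 24 h, tested at 12 ug/mL (on this read-out lower numbers stand for a stronger effect and higher numbers for a weaker effect at the one concentration tested), where compound 1 gives 55.1%. Going by the values given here, compound 2 `O=C(CSc1nnnn1-c1ccccc1)N/N=c1/scc(-c2ccc(F)cc2)n1-c1ccccc1` gives 60%, and the one measured step, a number 4.9 percentage points higher from compound 1 to compound 2 (within the scatter), shows no movement beyond the scatter. Compound 3 `Cn1nnnc1SCC(=O)N/N=c1/scc(-c2ccc(C#N)cc2)n1-c1ccccc1` gives 53.9%, the lowest of the three numbers, though within the scatter of both compound 1 and compound 2. Compound 4 `N#Cc1ccc(-c2cs/c(=N/NC(=O)CSc3nnnn3-c3ccccc3)n2-c2ccccc2)cc1` is not yet measured; it differs from compound 3 as follows: phenyl in place of methyl on an aromatic nitrogen. Among the compounds with values here, no measured step covers this change; the only step in hand concerns a different position and was within the scatter. Compound 1 and compound 2, which carry the same 1-phenyl-1H-tetrazol-5-yl group, sit close to compound 3. The expected step is a number 2.1 percentage points higher from compound 3 to compound 4 (within the scatter), none beyond the scatter. Compound 4 is therefore estimated at 56%, ranging from 46% to 66%.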

Compound 4, a percentage reported as activity, at one concentration (the size of the read-out at that concentration, not a potency): 74.1%
Estimate against measurement, compound 4: 18.1 percentage points below; the measured number lies above the stated range.
By their numbers in this assay, from the lowest: compounds 3, 1 and 2 (each within the scatter of the next); then compound 4.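

In this assay the change from 1-methyl-1H-tetrazol-5-yl to 1-phenyl-1H-tetrazol-5-yl gives a number 20.2 percentage points higher from compound 3 to compound 4 (beyond the scatter) and so moves toward a weaker effect, the first movement beyond the scatter at this position. With the 1-phenyl-1H-tetrazol-5-yl group held, cyano on the aromatic carbon gives a number 14.1 percentage points higher from compound 2 to compound 4 (beyond the scatter) in place of fluoro and a number 19 percentage points higher from compound 1 to compound 4 (beyond the scatter) in place of methyl, so the aromatic carbon also matters here. Nothing at hand explains these steps.

Open, from the compounds shown here alone, is whether ethyl or benzyl on the aromatic nitrogen falls nearer methyl or phenyl. Also open, going by these compounds, is whether an amine on the aromatic carbon behaves like cyano.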